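A few compounds are considered here, and "the series" means these few. Any claim that something is new, unique, unknown or untested is made for them only; others in the source may bear on it.

Three compounds share one core and differ only in the group on one aromatic carbon. Compound 3 `Cc1nc(N)c2c(I)cn([C@@H]3O[C@H](CO)[C@@H](O)[C@H]3O)c2n1` carries an iodo group, and in a functional assay on K562 cells (Homo sapiens), read by MTT assay, with a stated time of 72 h (a higher number here means a weaker inhibitor, a lower number a stronger inhibitor), compound 3 gives 1110 nM, the lowest of the two numbers measured. Compound 2 `C#Cc1cn([C@@H]2O[C@H](CO)[C@@H](O)[C@H]2O)c2nc(C)nc(N)c12` carries an ethynyl group; in this assay compound 2 gives 3290 nM, and the step of a 3.0-fold lower number from compound 2 to compound 3 (0.47 log units; beyond the scatter) is modest. Compound 1 `Cc1nc(N)c2c(-c3cccs3)cn([C@@H]3O[C@H](CO)[C@@H](O)[C@H]3O)c2n1` carries a thiophen-2-yl group. In this assay compound 1 reaches only the limit of > 20000 nM. Against that limit, the change to the ethynyl group gives an at least 6.0-fold lower number from compound 1 to compound 2 (0.78 log units; beyond the scatter) and the change to iodo gives an at least 18-fold lower number from compound 1 to compound 3 (1.25 log units; beyond the scatter); both figures rest on (the limit of > 20000 nM in this assay, at which 1 of the 3 values shown sits).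

Compound 4 `Cc1nc(N)c2c(-c3ccoc3)cn([C@@H]3O[C@H](CO)[C@@H](O)[C@H]3O)c2n1` has not yet been measured. The change is furan-3-yl in place of iodo on an aromatic carbon. Among the measured compounds shown here, the one measured step that involves a five-membered aromatic ring at this position, the large one between compound 1 and compound 3, ran strongly in favour of iodo, so putting a ring back in place of iodo is expected to raise the number well beyond the scatter. For compound 4 in this assay the expected step is a 14-fold higher number from compound 3 to compound 4 (1.13 log units; beyond the scatter). Compound 4 is estimated at 15000 nM, within a range from 4000 nM to 60000 nM, with a real chance that only a limit is reported.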

Compound 4, half-maximal inhibitory concentration: > 20000 nM
Compound 4: no number, only a limit (the forecaster's own chance of this, stated with the estimate: 45%); middle value at least 1.3-fold (0.12 log units) from the limit.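

In this assay compound 4 gives only a limit, > 20000 nM. Replacing iodo with furan-3-yl gives an at least 18-fold higher number from compound 3 to compound 4 (1.25 log units; beyond the scatter), and replacing ethynyl with it gives an at least 6.0-fold higher number from compound 2 to compound 4 (0.78 log units; beyond the scatter), so the poor result of compound 1 is no longer tied to thiophen-2-yl alone: among the four compounds, both groups with a five-membered aromatic ring on this aromatic carbon fall behind iodo and ethynyl, and no compound shown goes against this. The step between compound 1 and compound 4 cannot be read because both stand at a limit: the limit of > 20000 nM in this assay, at which 2 of the 4 values shown sit.

The compounds shown do not separate the effect of having an aromatic ring at this place from the effect of simply adding more heavy atoms, and they do not show how far above the limit either ring compound lies. A small non-aromatic ring such as cyclopropyl, a short chain such as methyl or a halogen such as bromo would help to show which of these readings holds, and whether any group here can give a lower number than iodo.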